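Moving a Nitrooxymethyl Group Around a Phenyl Ring

The compounds below may be only part of what the source reports. "The series", "measured", "known", "first", "only" and "open" are said of these compounds alone.

Compound 1 `CC(=O)Oc1ccccc1C(=O)O[C@H]1CO[C@H]2[C@@H]1OC[C@H]2OC(=O)c1cccc(O)c1`: 0.0183 h
Compound 2 `CC(=O)Oc1ccccc1C(=O)O[C@H]1CO[C@H]2[C@@H]1OC[C@H]2OC(=O)c1ccncc1`: 0.0617 h
Compound 3 `CC(=O)Oc1ccccc1C(=O)O[C@H]1CO[C@H]2[C@@H]1OC[C@H]2OC(=O)c1ccccc1CO[N+](=O)[O-]`: 0.045 h

These three compounds share one core and differ only in the aromatic group attached to one carbonyl carbon. In an ADME assay on a cell-free system (plasma, Homo sapiens) for metabolic stability, with Plasma (Rattus norvegicus) as the target, read by HPLC, at pH 7.4 (a lower number here means that the compound disappears faster, a higher number that the compound lasts longer), compound 3 gives 0.045 h, the second highest of the three numbers; the nearest neighbour, compound 2, gives 0.0617 h, and the step of a 1.4-fold lower number from compound 2 to compound 3 (0.14 log units; within the scatter) lies within the scatter, whereas the step of a 2.5-fold higher number from compound 1 to compound 3 (0.39 log units; beyond the scatter) lies beyond it. Compound 4 `CC(=O)Oc1ccccc1C(=O)O[C@H]1CO[C@H]2[C@@H]1OC[C@H]2OC(=O)c1ccc(CO[N+](=O)[O-])cc1` has not yet been measured. It differs from compound 3 by 4-((nitrooxy)methyl)phenyl in place of 2-((nitrooxy)methyl)phenyl on a carbonyl carbon. Going by the values given here, none of the measured steps moves a group from one position to another on the same ring: the steps of a 3.4-fold higher number from compound 1 to compound 2 (0.53 log units; beyond the scatter) and a 2.5-fold higher number from compound 1 to compound 3 (0.39 log units; beyond the scatter) exchange the whole aromatic group and were modest, and the step of a 1.4-fold lower number from compound 2 to compound 3 (0.14 log units; within the scatter) was within the scatter. A move of the same group within one ring is a smaller change than any of these, so no step beyond the scatter is expected in this assay, and the estimated step of no change at the digits printed from compound 3 to compound 4 (within the scatter) is essentially flat. Compound 4 is therefore expected to give about 0.045 h, with a range from 0.02 h to 0.1 h.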

Compound 4, half-life: 0.1 h
Compound 4: middle estimate off by 2.2-fold (0.35 log units), on the low side, within the range that was stated.
By their numbers in this assay, from the lowest: compound 1; then compounds 3, 2 and 4 (each within the scatter of the next, the first and the last beyond it).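

In this assay, the change of 4-((nitrooxy)methyl)phenyl for 2-((nitrooxy)methyl)phenyl on a carbonyl carbon gives a 2.2-fold higher number from compound 3 to compound 4 (0.35 log units; beyond the scatter), so a rearrangement that leaves the atoms of the group unchanged can still shift this number. Exchanging the whole aromatic group does not always do more: the step of a 1.6-fold higher number from compound 2 to compound 4 (0.21 log units; within the scatter) is smaller than that rearrangement and gives no order between these two compounds, while the step of a 5.5-fold higher number from compound 1 to compound 4 (0.74 log units; beyond the scatter) is the widest shown. Nothing available here explains the difference between the two arrangements.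

This is a single pair, so it cannot show whether other groups respond in the same way. From the compounds shown here alone, an amine or a carboxylic acid at these ring positions remains open, as does a longer chain carrying the nitrooxy group.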